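Ring amide nitrogen substituent: amide side chain to benzyl

The compounds below may be only part of what the source reports. "The series", "measured", "known", "first", "only" and "open" are said of these compounds alone.

Measured in a functional assay on HT-1080 cells (Homo sapiens) for inhibition, read by MTT assay, with a stated time of 48 h; on this read-out lower numbers stand for stronger inhibition and higher numbers for weaker inhibition:
compound 1 `COc1cc(-c2nc3cc(/C=C4\SC(=O)N(CC(=O)N5CCOCC5)C4=O)ccc3[nH]2)cc(OC)c1OC`: 1680 nM
compound 2 `COc1cc(-c2nc3cc(/C=C4\SC(=O)N(CC(=O)N5CCCC5)C4=O)ccc3[nH]2)cc(OC)c1OC`: 2470 nM

Compound 2 gives the higher of the two numbers in this assay; its nearest neighbour is compound 1, and a 1.5-fold higher number from compound 1 to compound 2 (0.17 log units; within the scatter), so the two are not separated. Compound 3 `COc1cc(-c2nc3cc(/C=C4\SC(=O)N(Cc5ccccc5)C4=O)ccc3[nH]2)cc(OC)c1OC` is the next step: phenyl in place of (pyrrolidin-1-yl)carbonyl on a saturated chain carbon bound to an amide-type nitrogen in a ring. Among the compounds with values here, the only measured step, from compound 1 to compound 2, exchanges one cyclic amine on the carbonyl for another and leaves the carbonyl in place, so it bears on this change only loosely; no measured pair removes the amide carbonyl. On that basis no step beyond the scatter is expected for compound 3 in this assay, but the range is kept wide. Compound 3 is estimated at 2500 nM (range 800 nM to 8000 nM), which means an expected 1.0-fold higher number from compound 2 to compound 3 (0.01 log units; within the scatter).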

Compound 3, half-maximal inhibitory concentration: 660 nM
Beside the measured number, compound 3's estimate is 3.8-fold (0.58 log units) above it, outside the stated range (below it).
By their numbers in this assay, from the lowest: compound 3; then compounds 1 and 2 (each within the scatter of the next).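

In this assay, phenyl in place of the (pyrrolidin-1-yl)carbonyl or (morpholin-4-yl)carbonyl group on the saturated chain carbon gives a 3.7-fold lower number from compound 2 to compound 3 (0.57 log units; beyond the scatter) and a 2.5-fold lower number from compound 1 to compound 3 (0.41 log units; beyond the scatter) and places compound 3 lowest of the three. The exchange of one cyclic amine for the other did not separate compound 1 and compound 2 (a 1.5-fold higher number from compound 1 to compound 2 (0.17 log units; within the scatter)), whereas replacing the whole carbonyl-bearing group moves the number beyond the scatter, so this position does respond to a change in the series. Nothing shown here gives a reason for this step.

The benzyl change removes the carbonyl and the cyclic amine and brings in the phenyl ring in a single step, so the compounds shown do not assign the step to any one of these. A plain methyl group, a longer phenylethyl chain or a benzyl ring carrying fluorine or methoxy would help to separate these contributions.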